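The source may hold more compounds than are shown below. What is called first, only, known or untested is meant among the compounds shown, and "the series" means these compounds.

Measured so far:
compound 1 `C=CCOn1c(-c2cccc(C#N)c2)nc(C)c1C(=O)OCC`: 5860 nM
compound 2 `CCOC(=O)COn1c(-c2cccc(C#N)c2)nc(C)c1C(=O)OCC`: 6800 nM
compound 3 `CCOC(=O)c1c(C)nc(-c2cccc(C#N)c2)n1OCc1cccc(Cl)c1`: 19400 nM

These values come from a functional assay on a cell-free system (plasma, Oryctolagus cuniculus) for inhibition, with stated times of 5 min, 1 min and 6 min; a lower number here means a stronger inhibitor, a higher number a weaker inhibitor. Compound 3, at 19400 nM, has the highest number of the three, which makes it the weakest inhibitor among them. Compound 4 `CCOC(=O)c1c(C)nc(-c2cccc(C#N)c2)n1OCc1ccc(C)cc1` keeps the shared core but has 4-methylphenyl in place of 3-chlorophenyl on a saturated chain carbon bound to an oxygen on an aromatic ring.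

Two measured steps change the group at this place and end on a 3-chlorophenyl: a 3.3-fold higher number from compound 1 to compound 3 (0.52 log units; beyond the scatter) and a 2.9-fold higher number from compound 2 to compound 3 (0.46 log units; beyond the scatter). Both are modest. A third, a 1.2-fold higher number from compound 1 to compound 2 (0.06 log units; within the scatter), stays within the scatter. None of these steps exchanges one substituted phenyl for another, so the guidance is only indirect. Both groups here are substituted phenyls, so no step beyond the scatter is expected in this assay, and direction remains uncertain. The expected result is a 1.2-fold lower number from compound 3 to compound 4 (0.08 log units; within the scatter). For compound 4 the estimated value is 16000 nM, with an expected range from 7000 nM to 36000 nM.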

Compound 4, half-maximal inhibitory concentration: 6310 nM
Compound 4: the middle estimate sits 2.5-fold (0.40 log units) above what was measured; measured number below the stated range.
By their numbers in this assay, from the lowest: compounds 1, 4 and 2 (each within the scatter of the next); then compound 3.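

In this assay, exchanging one substituted phenyl for another at this place is not a silent change: there is a 3.1-fold lower number from compound 3 to compound 4 (0.49 log units; beyond the scatter), so an aromatic ring on this chain carbon does not by itself bring the weaker number of compound 3. Compound 4 instead stays level with the compounds that carry no ring in this group, with a 1.1-fold lower number from compound 2 to compound 4 (0.03 log units; within the scatter) and a 1.1-fold higher number from compound 1 to compound 4 (0.03 log units; within the scatter), leaving compound 3 as the one that goes against this level result. Nothing available here gives a reason for the gap between 3-chlorophenyl and 4-methylphenyl.

This change swaps both the ring substituent and its printed ring number, so the compounds shown cannot say which of the two matters; 4-chlorophenyl and 3-methylphenyl would separate them. As far as these compounds go, how an unsubstituted phenyl or a carboxylic acid would read at this place also remains open.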